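A few compounds are considered here, and "the series" means these few. Any claim that something is new, unique, unknown or untested is made for them only; others in the source may bear on it.

Compound 1 `C#CC[C@@H]1O[C@H](COCc2ccccc2)[C@@H](OCc2ccccc2)[C@H](OCc2ccccc2)[C@H]1O`, compound 2 `CCCC[C@@H]1O[C@H](COCc2ccccc2)[C@@H](OCc2ccccc2)[C@H](OCc2ccccc2)[C@H]1O` and compound 3 `CCC[C@@H]1O[C@H](COCc2ccccc2)[C@@H](OCc2ccccc2)[C@H](OCc2ccccc2)[C@H]1O` share one core and differ only in the chain attached to a ring carbon. In a functional assay on HL-60 cells (Homo sapiens) for antiproliferative activity, read by MTT assay (on this read-out higher numbers stand for weaker inhibition and lower numbers for stronger inhibition), compound 3 gives 11700 nM. For compound 2 the outcome in this assay is reported only as "not active" (no number reported), with no number behind it. For compound 1 the outcome in this assay is likewise given as "not active" (no number reported). Compound 2 thus stands without a measured figure in this series.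

Compound 4 `CCCC[C@H]1O[C@H](COCc2ccccc2)[C@@H](OCc2ccccc2)[C@H](OCc2ccccc2)[C@H]1O` keeps every atom and bond of compound 2: the two compounds have the same atoms and bonds and differ only in configuration as drawn: 1 of 5 stereo elements differ; a stereocentre at a saturated ring carbon is drawn S in compound 2 and R in compound 4. Going by the values given here, no measured pair here shows how such a change in configuration moves the read-out, so the expectation is a weak result, or no change beyond the scatter. The weak figure of compound 3 at 11700 nM points the same way. For compound 4 the estimate in this assay is 20000 nM, expected between 5000 nM and 80000 nM, with a real chance that again only "not active" is reported.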

Compound 4, half-maximal inhibitory concentration: "not active" (no number reported)
The entry for compound 4 holds no number, and the estimate cannot be compared.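

Compound 2 and compound 4 are both reported without a number in this assay, so no step can be read between them. Going by these compounds, whether the configuration at that ring carbon moves the activity at all stays open.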